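Replacing the piperidine arm with a benzoate ester

The source may report more compounds than this note shows. Statements on the series, on what has been measured and on what is new or still open speak of the compounds shown alone.

Compound 3 `COC(=O)CC1CCN(C[C@H]2CN(c3ccc(-n4cc(-c5ccccn5)cn4)c(F)c3)C(=O)O2)CC1` stands lowest of the three measured compounds in a physicochemical assay for solubility, read by HPLC, with a stated time of 24 h (on this read-out lower numbers stand for lower solubility and higher numbers for higher solubility), at 92100 nM. Compound 1 `CCN1CCN(C[C@H]2CN(c3ccc(-n4cc(-c5ccccn5)cn4)c(F)c3)C(=O)O2)CC1` gives 706000 nM and compound 2 `O=C1O[C@@H](CN2CCCCC2)CN1c1ccc(-n2cc(-c3ccccn3)cn2)c(F)c1` gives 219000 nM. Each earlier step changed the same arm on a saturated chain carbon bound to a saturated ring carbon, and each lowered the read-out: a 3.2-fold lower number from compound 1 to compound 2 (0.51 log units; beyond the scatter), a 7.7-fold lower number from compound 1 to compound 3 (0.88 log units; beyond the scatter), and a 2.4-fold lower number from compound 2 to compound 3 (0.38 log units; beyond the scatter). Compound 4 `O=C(OC[C@H]1CN(c2ccc(-n3cc(-c4ccccn4)cn3)c(F)c2)C(=O)O1)c1ccccc1` continues in that place with benzoyloxy in place of 4-((methoxycarbonyl)methyl)piperidin-1-yl on a saturated chain carbon bound to a saturated ring carbon. What is counted is a ring nitrogen leaving while a carbon-only aromatic ring enters and one acceptor is lost. Among the measured compounds shown here, no measured step removes the nitrogen-containing ring, so the earlier steps bear on compound 4 only by showing the direction this position has taken so far, with the larger of them the step from compound 1 to compound 3. A further drop beyond the scatter is therefore expected for compound 4, likely larger than the earlier single steps. The expected step from compound 3 to compound 4 is a 7.7-fold lower number from compound 3 to compound 4 (0.89 log units; beyond the scatter). Compound 4 is estimated at 12000 nM in this assay, within a range from 3000 nM to 50000 nM.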

Compound 4, solubility: <= 65400 nM
Compound 4: a limit, no number; the forecaster's own chance of this, stated with the estimate: 5%; the middle value does not contradict the limit.
By their numbers in this assay, from the lowest: compound 3; then compound 2; then compound 1. At a limit, below all of these: compound 4.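

In this assay compound 4 returns a limit and not a number: the limit of <= 65400 nM in this assay, at which 1 of the 4 values shown sits.
Among the compounds shown here, with benzoyloxy on the saturated chain carbon, the comparison with the piperidine compounds gives an at least 3.3-fold lower number from compound 2 to compound 4 (0.52 log units; beyond the scatter) and an at least 10-fold lower number from compound 1 to compound 4 (1.03 log units; beyond the scatter), the second being the first step at this place that is printed as large. The comparison with the closest earlier arm is less firm, since an at least 1.4-fold lower number from compound 3 to compound 4 (0.14 log units; that floor lies within the scatter) has a floor within the usual scatter, so the limit alone does not separate those two compounds. For the compounds shown here, what the result adds is that an arm with no ring nitrogen, carrying a carbon-only aromatic ring, stays under the limit and so falls clearly short of compound 1 and compound 2, which no earlier step could show, since every earlier arm kept its nitrogen-containing ring.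

The compounds shown leave open where compound 4 lies under its limit, and whether the departure of the ring nitrogen or the arrival of the aromatic ring carries the change, as both happen in one step. They also leave open how a carboxylic acid, a morpholine ring or an open-chain amine would read on this saturated chain carbon.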